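This account rests on a few compounds, and the source may have more. Where it says the series, first, only, none or still open, it means among the compounds named here.

Compound 2 `CC(C)c1cccc(-c2nc(C(F)(F)F)ccc2CNC(=O)Nc2cccc3[nH]c(=O)ccc23)c1` gives 1.35 nM in an assay on HEK cells for antagonist activity at transient receptor potential cation channel subfamily V member 1 (Homo sapiens), read by FLIPR; on this read-out higher numbers stand for weaker inhibition and lower numbers for stronger inhibition; this is the lowest of the two numbers, but its gap to compound 1 `O=C(NCc1ccc(C(F)(F)F)nc1OCC1CCCC1)Nc1cccc2[nH]c(=O)ccc12`, which gives 2.18 nM, is a 1.6-fold lower number from compound 1 to compound 2 (0.21 log units; within the scatter), so the two are not separable. Compound 3 `O=C(NCc1ccc(C(F)(F)F)nc1-c1ccc(F)cc1)Nc1cccc2[nH]c(=O)ccc12` is not yet measured; it differs from compound 2 by 4-fluorophenyl in place of 3-isopropylphenyl on an aromatic carbon. For the measured compounds named here, the only measured step at this position is a 1.6-fold lower number from compound 1 to compound 2 (0.21 log units; within the scatter), so no step beyond the scatter is expected in this assay. For compound 3 the expected step is a 1.5-fold higher number from compound 2 to compound 3 (0.17 log units; within the scatter), giving an estimated 2 nM with a range from 0.7 nM to 6 nM.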

Compound 3, half-maximal inhibitory concentration: 1.93 nM
Compound 3: middle estimate off by 1.0-fold (0.02 log units), on the high side; the measured number falls inside the stated range.
By their numbers in this assay, from the lowest: compounds 2, 3 and 1 (each within the scatter of the next).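

In this assay, the aromatic carbon next to the ring nitrogen accepts 4-fluorophenyl in place of 3-isopropylphenyl (a 1.4-fold higher number from compound 2 to compound 3 (0.16 log units; within the scatter)) and in place of cyclopentylmethoxy (a 1.1-fold lower number from compound 1 to compound 3 (0.05 log units; within the scatter)). Two aryl groups of 7 and 9 heavy atoms and the cyclopentylmethoxy group therefore all lie within the scatter of one another, so the three compounds show no preference among these groups at this position. No evidence is available to account for this. Still open, going by these compounds, is whether an amine or a carboxylic acid at this position would give a step beyond the scatter.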